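A few compounds are considered here, and "the series" means these few. Any claim that something is new, unique, unknown or untested is made for them only; others in the source may bear on it.

Measured in a functional assay on SK-MEL-28 cells (Homo sapiens) for inhibition; on this read-out lower numbers stand for stronger inhibition and higher numbers for weaker inhibition:
- Compound 1 `COCCOc1cc(/C=C\c2ccc3ccccc3c2)ccc1OC`: 2990 nM
- Compound 2 `COc1ccc(/C=C/c2ccc3ccccc3c2)cc1F`: > 5000 nM, a limit
- Compound 3 `COc1ccc(/C=C/c2ccc3ccccc3c2)cc1[N+](=O)[O-]`: > 5000 nM, a limit

Compound 3 has no exact number and stands only at the limit of > 5000 nM. Compound 2 sits at the same limit, as the limit of > 5000 nM in this assay, at which 2 of the 3 values shown sit, records. Compound 4 `COc1ccc(/C=C\c2ccc3ccccc3c2)cc1[N+](=O)[O-]` is the next compound to be considered, and it relates to compound 3 as follows: the two compounds have the same atoms and bonds and differ only in configuration as drawn: 1 of 1 stereo elements differ; a double bond is drawn E in compound 3 and Z in compound 4.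

For the measured compounds named here, the only measured step, a step that the two limits leave unreadable from compound 2 to compound 3, gives no size to carry over, and no measured pair isolates this change of configuration. The nearest guide is compound 1, which also has the double bond drawn Z, although it differs elsewhere, and gives 2990 nM. On that single value from compound 1, stronger inhibition is expected for compound 4 in this assay, though with wide uncertainty and a real chance of another limit. The expected change is an at least 3.3-fold lower number from compound 3 to compound 4 (0.52 log units; beyond the scatter). For compound 4 the estimated value is 1500 nM. The expected range runs from 250 nM to 5000 nM.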

Compound 4, half-maximal inhibitory concentration: > 20000 nM
Compound 4: only a limit was reported; the forecaster's own chance of this, stated with the estimate: 30%; middle value at least 13-fold (1.12 log units) from the limit.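

In this assay compound 4 is recorded only as a limit, > 20000 nM. For the compounds shown here, with the double bond drawn Z in both compounds, nitro in place of 2-methoxyethoxy on an aromatic carbon gives an at least 6.6-fold higher number from compound 1 to compound 4 (0.82 log units; beyond the scatter), the first readable step at this position, so a Z double bond alone does not bring the number down to that of compound 1. The steps between limits cannot be read, so the change from E to Z has no measurable size here, even though this pair isolates it: the fact that compounds 3 and 4 differ only in the configuration as drawn

It remains open how much the configuration matters when 2-methoxyethoxy is present, since the compounds shown offer no E partner for compound 1. As far as these compounds go, it is also open whether an amine, a hydroxyl or a longer ether chain on this aromatic carbon would give a number rather than a limit.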